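Swapping a thiazole for an amide on a shared core

The source may hold more compounds than are shown below. What is called first, only, known or untested is meant among the compounds shown, and "the series" means these compounds.

Of the compounds shown here, three built on a shared core have been tested in an ADME assay on PC-3 cells (Homo sapiens) for cytotoxicity, read by WST assay, tested at 100 uM; on this read-out higher numbers stand for more inhibition at the one concentration tested (going by the name of the read-out) and lower numbers for less inhibition. Compound 1 `O=C(Nc1cccc(Oc2ccccn2)c1)C1CCCN(C(=O)c2cc(C(F)(F)F)cc(C(F)(F)F)c2)C1` gives 0%, compound 2 `COc1cccc(C(=O)N2CCCC(C(=O)Nc3ccc(Cl)cc3)C2)c1` gives 0%, and compound 3 `Cc1nc(-c2cccc(C(=O)N3CCCC(C(=O)Nc4ccc(Cl)cc4)C3)c2)cs1` gives 1%. Compound 3 thus holds the highest of the three numbers on paper, but its gaps to compound 1 and to compound 2 both fall within the scatter, so none of the three can be told apart from the others. For the measured compounds named here, the one step between compounds that differ in a single place, a number 1 percentage points higher from compound 2 to compound 3 (within the scatter), is likewise within the scatter.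

Compound 4 `CC(C)(C)CC(=O)Nc1cccc(C(=O)N2CCCC(C(=O)Nc3ccc(Cl)cc3)C2)c1` is the next compound. It differs from compound 3 as follows: (neopentylcarbonyl)amino in place of 2-methyl-1,3-thiazol-4-yl on an aromatic carbon. Going by the values given here, no measured step exchanges a five-membered aromatic ring for a group with no ring in this way, so the only guide is the step from compound 2 to compound 3, which barely moved the number. Since all three measured compounds sit near the floor of the read-out in this assay, compound 4 is expected to sit there too, with an estimated step of a number 1 percentage points higher from compound 3 to compound 4 (within the scatter), giving an estimated 2% with a range from 0% to 12%.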

Compound 4, a percentage reported as inhibition, at one concentration (the size of the read-out at that concentration, not a potency): 0%
Beside the measured number, compound 4's estimate is 2 percentage points above it, within the range that was stated.
By their numbers in this assay, from the lowest: compounds 1, 2, 4 and 3 (each within the scatter of the next).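

In this assay, a third kind of group on this aromatic carbon, meta to a large group, leaves the number where it was: the change gives a number 1 percentage points lower from compound 3 to compound 4 (within the scatter), and the swap for methoxy gives no change at the digits printed from compound 2 to compound 4 (within the scatter). Exchanging the five-membered aromatic ring for a chain with no ring and a hydrogen-bond donor therefore leaves no readable mark, so methoxy, 2-methyl-1,3-thiazol-4-yl and (neopentylcarbonyl)amino cannot be told apart here. Nothing available explains why the number stays put.

On these data alone, all the numbers so far sit close together near the bottom of the read-out, so it remains unknown whether any group at this position can shift them. A primary amine or a carboxylic acid here might lift the number clear of the scatter, or it might stay just as flat.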